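The source may hold more compounds than are shown below. What is called first, only, known or untested is meant among the compounds shown, and "the series" means these compounds.

Of the compounds shown here, three have numbers so far in a functional assay on A549 cells (Homo sapiens) for cytotoxicity, read by MTT assay, with a stated time of 72 h; a lower number here means a stronger inhibitor, a higher number a weaker inhibitor: compound 1 (`Cc1ccc(NC(=O)CN2CCN(c3nnc(Cc4ccncc4)c4ccccc34)CC2)c(C)c1`) gives 45000 nM and compound 3 (`O=C(CN1CCN(c2nnc(Cc3ccccc3)c3ccccc23)CC1)Nc1ccc(F)c(F)c1`) gives 10100 nM, while compound 2 (`O=C(CN1CCN(c2nnc(Cc3ccncc3)c3ccccc23)CC1)Nc1ccc(Br)cc1`) is the lowest at 2710 nM and so the strongest inhibitor of the three. Compound 4 (`Cc1ccc(F)cc1NC(=O)CN1CCN(c2nnc(Cc3ccncc3)c3ccccc23)CC1`) has 5-fluoro-2-methylphenyl in place of 4-bromophenyl on an amide-type nitrogen. Among the compounds with values here, the one measured step at this place is large, a 17-fold lower number from compound 1 to compound 2 (1.22 log units; beyond the scatter) (4-bromophenyl in place of 2,4-dimethylphenyl). The entering group shares the name part 2-methyl with the group of compound 1, so part of that step is expected to return, not all of it. The expected change in this assay is a 5.5-fold higher number from compound 2 to compound 4 (0.74 log units; beyond the scatter) and would lie beyond the scatter. For compound 4 the estimate is 15000 nM (range 5000 nM to 40000 nM).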

Compound 4, half-maximal inhibitory concentration: 38900 nM
Estimate against measurement, compound 4: 2.6-fold (0.41 log units) below; low and high end bracket the measured number.
By their numbers in this assay, from the lowest: compound 2; then compound 3; then compounds 4 and 1 (each within the scatter of the next).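

The change from 4-bromophenyl to 5-fluoro-2-methylphenyl costs far more in this assay than a partial return of the earlier step (a 14-fold higher number from compound 2 to compound 4 (1.16 log units; beyond the scatter)). The two groups carrying 2-methyl end up level on this amide-type nitrogen (a 1.2-fold lower number from compound 1 to compound 4 (0.06 log units; within the scatter)), so among compounds 1, 2 and 4 only the 4-bromophenyl of compound 2 stands apart. Nothing measured here explains this difference.
From the compounds shown here alone, it remains open whether the higher number goes with the 2-methyl group or with the loss of bromine. A plain 2-methylphenyl or a 4-chlorophenyl group on the same core would help separate these two readings.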